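From 2-Methylphenyl to 4-Methylpyridin-3-yl

This account rests on a few compounds, and the source may have more. Where it says the series, first, only, none or still open, it means among the compounds named here.

In a functional assay on MCF7 cells (Homo sapiens) for cytotoxicity, read by CellTiter-Glo, with a stated time of 5 days (on this read-out lower numbers stand for stronger inhibition and higher numbers for weaker inhibition), compound 1 (`CC/C(=C(/c1csc(/C=C/C(=O)O)c1)c1ccc2[nH]ncc2c1)c1ccccc1`) reads 2900 nM and compound 2 (`CC/C(=C(/c1ccc(/C=C/C(=O)O)cc1)c1ccc2[nH]ncc2c1)c1cccc(C#N)c1`) reads 100 nM while compound 3 (`CC/C(=C(/c1ccc(/C=C/C(=O)O)cc1)c1ccc2[nH]ncc2c1)c1ccccc1C`) reads 4 nM and holds the lowest of the three numbers. Compound 4 (`CC/C(=C(/c1ccc(/C=C/C(=O)O)cc1)c1ccc2[nH]ncc2c1)c1cnccc1C`) has not yet been measured. It differs from compound 3 at a single place, on a double-bonded chain carbon bound to a double-bonded chain carbon and a saturated chain carbon, where 4-methylpyridin-3-yl stands in place of 2-methylphenyl (4-methylpyridin-3-yl in place of 2-methylphenyl on a double-bonded chain carbon bound to a double-bonded chain carbon and a saturated chain carbon). Among the compounds with values here, one measured step bears on that place. It is a 25-fold lower number from compound 2 to compound 3 (1.40 log units; beyond the scatter) and comes with 2-methylphenyl replacing 3-cyanophenyl, so a change at this place has moved the number a long way at least once. Within the data shown here, no measured compound carries 4-methylpyridin-3-yl, and the data therefore do not fix the size of the new step. A modest move toward a higher number is expected, since 4-methylpyridin-3-yl differs from 2-methylphenyl only in its ring. The estimated result is a 3.0-fold higher number from compound 3 to compound 4 (0.48 log units; beyond the scatter) and so a far smaller move in this assay than the other step at this place. Compound 4 is estimated at 12 nM within an expected range of 3 nM to 50 nM for this measurement.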

Compound 4, half-maximal inhibitory concentration: 150 nM
Estimate against measurement, compound 4: 13-fold (1.10 log units) below; the measured number lies above the stated range.
By their numbers in this assay, from the lowest: compound 3; then compounds 2 and 4 (each within the scatter of the next); then compound 1.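

In this assay, the exchange of 2-methylphenyl for 4-methylpyridin-3-yl gives a 38-fold higher number from compound 3 to compound 4 (1.57 log units; beyond the scatter), so this place responds strongly even when the heavy-atom count stays the same and one ring carbon gives way to a nitrogen, which adds a single hydrogen-bond acceptor. The earlier step at this place came with a change of substituent as well as of its ring position, whereas here the methyl group stays on the ring and the low number of compound 3 is still not kept; the other new step, a 1.5-fold higher number from compound 2 to compound 4 (0.18 log units; within the scatter), lies within the scatter, so the 3-cyanophenyl and 4-methylpyridin-3-yl groups cannot be told apart on this read-out, though they differ in both ring and substituent. Nothing measured on these groups beyond this read-out is at hand to account for the step.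

The compounds shown leave open whether the ring nitrogen would have the same effect elsewhere in the ring, or with the methyl group absent. They also leave open how far the number of compound 3 would hold with an ethylphenyl, chlorophenyl or methoxyphenyl group at this place.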